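Thioether to aryl ether on the fused core of compound 3

A few compounds are considered here, and "the series" means these few. Any claim that something is new, unique, unknown or untested is made for them only; others in the source may bear on it.

Measured compounds:
compound 1 `CCOC(=O)[C@H](CCC(=O)O)NC(=O)c1ccc(Sc2nc3cc(N)cc(N)c3nc2-c2ccccc2)cc1` — 95500 nM
compound 2 `Nc1cc(N)c2nc(-c3ccccc3)c(NCc3ccc(F)cc3)nc2c1` — 8910 nM
compound 3 `COc1ccc(Sc2nc3cc(N)cc(N)c3nc2-c2ccccc2)cc1` — < 100000 nM

In a functional assay on UACC-257 cells (Homo sapiens) for inhibition, read by sulforhodamine B assay, with a stated time of 48 h (on this read-out higher numbers stand for lower toxicity in this test and lower numbers for higher toxicity in this test), compound 1 gives 95500 nM. Compound 2 gives 8910 nM in this assay. For compound 3 this assay returns only a limit, < 100000 nM, and not a number. Compound 3 therefore has no fixed place among the measured values; the step that the limit leaves unreadable from compound 2 to compound 3 cannot be read because of the limit of < 100000 nM in this assay, at which 1 of the 3 values shown sits.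

Compound 4 `Nc1cc(N)c2nc(-c3ccccc3)c(Oc3ccc(F)cc3)nc2c1` differs from compound 3 in one place: 4-fluorophenoxy in place of (4-methoxyphenyl)sulfanyl on an aromatic carbon. For the measured compounds named here, no measured step mirrors this change, and the only step that touches the same position, from compound 2 to compound 3, is itself unreadable, so nothing in the numbers sets a direction or size for it. The expected step that the limit leaves unreadable from compound 3 to compound 4 is accordingly placed near the centre of the measured values, with wide bounds. Compound 4 is estimated at 50000 nM, with a range from 10000 nM to 100000 nM, in this assay.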

Compound 4, concentration lethal to 50% of the cells: 77600 nM
Estimate against measurement, compound 4: 1.6-fold (0.19 log units) below, within the range that was stated.
By their numbers in this assay, from the lowest: compound 2; then compounds 4 and 1 (each within the scatter of the next).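

At this position the linking atoms matter in this assay: with a 4-fluoro-substituted ring in both groups, 4-fluorophenoxy in place of (4-fluorobenzyl)amino gives an 8.7-fold higher number from compound 2 to compound 4 (0.94 log units; beyond the scatter). For the compounds shown here, this is the first readable step at this aromatic carbon, and it shows that a change confined to this substituent can move the number beyond the scatter, towards lower toxicity in this test. The thioether-to-ether step itself still cannot be read, as compound 3 has only a limit: the limit of < 100000 nM in this assay, at which 1 of the 4 values shown sits.

The compounds shown leave open whether the step from compound 2 follows from the oxygen replacing the amine nitrogen or from the loss of the benzyl carbon. A 4-fluoroanilino group or a (4-fluorophenyl)sulfanyl group on the same carbon would separate these two changes.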